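Trifluoromethyl to chloro on a diaryl urea

This account rests on a few compounds, and the source may have more. Where it says the series, first, only, none or still open, it means among the compounds named here.

The series comprises compound 1 `O=C(Nc1cccc(-n2cc(-c3ccncc3)c(-c3cc(O)cc(Cl)c3)n2)c1)Nc1ccc(Cl)c(Cl)c1`, compound 2 `COc1cc(Cl)cc(-c2nn(-c3cccc(NC(=O)Nc4ccc(Cl)c(C(F)(F)F)c4)c3)cc2-c2ccncc2)c1` and compound 3 `COc1cc(Cl)cc(-c2nn(-c3cccc(NC(=O)Nc4ccc(Cl)c(Cl)c4)c3)cc2-c2ccncc2)c1`. In a functional assay on U-251 cells (Homo sapiens) for inhibition, read by sulforhodamine B assay, with a stated time of 48 h, tested at 0.01 uM (a lower number here means a stronger effect, a higher number a weaker effect of the compound at the concentration tested), compound 1 gives 96%. In this assay compound 2 gives 98%, which lies within the usual scatter of the value of compound 1, so the two stand together rather than in any order. Compound 3 differs from compound 2 by chloro in place of trifluoromethyl on an aromatic carbon. For compound 3 the step of a number 2 percentage points lower from compound 2 to compound 3 (within the scatter) in this assay is expected to be none beyond the scatter, and its value is estimated at 96%, with a range from 85% to 100%.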

Compound 3, a percentage reported as activity, at one concentration (the size of the read-out at that concentration, not a potency): 95%
The estimate for compound 3 lay 1 percentage points above the measured number; the range from low to high includes it.
By their numbers in this assay, from the lowest: compounds 3, 1 and 2 (each within the scatter of the next).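

In this assay, chloro in place of trifluoromethyl, ortho to a chloro group, gives a number 3 percentage points lower from compound 2 to compound 3 (within the scatter), so the two groups cannot be told apart at this position at the concentration tested. Methyl in place of hydrogen on the oxygen gives a number 1 percentage points lower from compound 1 to compound 3 (within the scatter), so that change cannot be told apart from the scatter either. No measurement shown here bears on the reason for these results.

Going by these compounds, whether an amine or a carboxylic acid at this position would separate from these compounds remains open. So does the effect of a longer chain on the oxygen.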